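Three Chalcone-Type Compounds and a Fourth Awaiting Measurement

This account rests on a few compounds, and the source may have more. Where it says the series, first, only, none or still open, it means among the compounds named here.

Measured so far:
- compound 1, `COc1ccc(-c2cn(-c3cccc(C(=O)/C=C/c4cc(OC)c(OC)c(OC)c4)c3)c(=O)[nH]2)cc1`: 1860 nM
- compound 2, `O=C(/C=C/c1cccc(O)c1)c1cccc(-n2cc(-c3ccc(Cl)cc3)[nH]c2=O)c1`: 2060 nM
- compound 3, `COc1ccc(-c2cn(-c3cccc(C(=O)/C=C/c4ccc(O)c(OC)c4)c3)c(=O)[nH]2)cc1`: 3350 nM

The three compounds share a core in which a three-carbon chain with a carbonyl links two aromatic groups, and a five-membered ring with two nitrogens carries a further aromatic group. In a functional assay on MDA-MB-435 cells (Homo sapiens) for inhibition (a higher number here means a weaker inhibitor of growth, a lower number a stronger inhibitor of growth), compound 1 gives 1860 nM, the smallest number of the three, yet its gaps to compound 2 and compound 3 are both within the usual scatter, so no order among the three is established.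

Compound 4, `COc1cc(/C=C/C(=O)c2cccc(-n3cc(-c4cc(OC)c(OC)c(OC)c4)[nH]c3=O)c2)cc(OC)c1OC`, has not been measured. It differs from compound 1 by 3,4,5-trimethoxyphenyl in place of 4-methoxyphenyl on an aromatic carbon. Going by the values given here, the one measured step, a 1.8-fold higher number from compound 1 to compound 3 (0.26 log units; within the scatter), changes the group at the end of the double-bonded chain, not the group on the five-membered ring, and it stays within the scatter. Among the compounds with values here, no measured pair touches the group on the five-membered ring, so there is nothing to suggest a shift in either direction; the expectation is therefore no step beyond the scatter.

Compound 4 is accordingly estimated at 1800 nM, with a range of 700 nM to 4500 nM, which is expected to mean a 1.0-fold lower number from compound 1 to compound 4 (0.01 log units; within the scatter).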

Compound 4, concentration for 50% growth inhibition: 2110 nM
Beside the measured number, compound 4's estimate is 1.2-fold (0.07 log units) below it; the range from low to high includes it.
By their numbers in this assay, from the lowest: compounds 1, 2, 4 and 3 (each within the scatter of the next).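

Going by these compounds alone, this is the first measured change to the group on the five-membered ring. In this assay, 3,4,5-trimethoxyphenyl in place of 4-methoxyphenyl gives a 1.1-fold higher number from compound 1 to compound 4 (0.05 log units; within the scatter), so a substantial enlargement of the group at this position does not produce a step beyond the scatter: the entering group has 12 heavy atoms against 8, and 3 hydrogen-bond acceptors against 1. No measurement here offers an explanation for this result.

The compounds shown carry only substituted phenyl groups at this position, so it remains open whether an amine, a carboxylic acid or a longer chain there would give a step beyond the scatter. Within the data shown here, it also remains open whether the same swap would give a similar result with 4-hydroxy-3-methoxyphenyl at the end of the double-bonded chain, since the only pair that differs at this position has 3,4,5-trimethoxyphenyl there.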